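The source may report more compounds than this note shows. Statements on the series, on what has been measured and on what is new or still open speak of the compounds shown alone.

Values in an ADME assay on HOS cells (Homo sapiens) for cytotoxicity; a higher number here means that more compound is tolerated, a lower number that less compound is tolerated:
- compound 1 `CN1CC(Cn2c(CN(C)C3CCCc4cccnc43)nc3ccccc32)C1`: 14000 nM
- compound 2 `CC(C)CN1CCC[C@H](Cn2c(CN(C)[C@H]3CCCc4cccnc43)nc3ccccc32)C1`: > 2000 nM (a limit, not a number)

For the measured compounds named here, compound 1 holds the only actual number so far. Compound 3 `CN1CCCCC1CCn1c(CN(C)C2CCCc3cccnc32)nc2ccccc21` is the next to be read against it: (1-methylpiperidin-2-yl)methyl in place of 1-methylazetidin-3-yl on a saturated chain carbon bound to an aromatic nitrogen. In words, (1-methylpiperidin-2-yl)methyl stands in place of 1-methylazetidin-3-yl on a saturated chain carbon bound to an aromatic nitrogen. No measured pair sizes this change, so only a modest downward move in this assay is expected. The expected move is a 1.4-fold lower number from compound 1 to compound 3 (0.15 log units; within the scatter), and it may stay within the scatter. For compound 3 the estimated value is 10000 nM, with an expected range from 3000 nM to 30000 nM.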

Compound 3, half-maximal cytotoxic concentration: 4900 nM
Beside the measured number, compound 3's estimate is 2.0-fold (0.31 log units) above it; the measured number falls inside the stated range.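

In this assay, the substituent on a saturated chain carbon bound to an aromatic nitrogen now has a sized effect: (1-methylpiperidin-2-yl)methyl in place of 1-methylazetidin-3-yl gives a 2.9-fold lower number from compound 1 to compound 3 (0.46 log units; beyond the scatter). This single step changes ring size and chain length together, so it cannot assign the drop to either one. Nothing measured here accounts for the step.

Open, from the compounds shown here alone, is whether a 1-methylpyrrolidin-3-yl group or an open-chain dimethylamino group at this place would read nearer compound 1 or compound 3.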